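The compounds below may be only part of what the source reports. "The series", "measured", "known", "first", "only" and "open" are said of these compounds alone.

Compound 2 `O=C(Nc1cc(C(F)(F)F)cc(C(F)(F)F)c1)c1cnc(Cl)nc1C(F)(F)F` is the most potent of the two numbered values in an assay on Jurkat cells for activation of nuclear factor NF-kappa-B complex (Homo sapiens) (on this read-out higher numbers stand for weaker inhibition and lower numbers for stronger inhibition), giving 50 nM. Compound 3 `O=C(Nc1cc(C(F)(F)F)cc(C(F)(F)F)c1)c1cnc(Cl)nc1-c1ccccc1` gives 400 nM, and the step of an 8.0-fold higher number from compound 2 to compound 3 (0.90 log units; beyond the scatter) is modest. Compound 1 `O=C(Nc1cc(C(F)(F)F)cc(C(F)(F)F)c1)c1cnc(C(F)(F)F)nc1C(F)(F)F` sits at a limit of this assay, > 10000 nM. The step of an at least 200-fold lower number from compound 1 to compound 2 (2.30 log units; beyond the scatter) is therefore large, a lower bound set by the limit of > 10000 nM in this assay, at which 1 of the 3 values shown sits. Compound 4 `O=C(Nc1cc(C(F)(F)F)cc(C(F)(F)F)c1)c1cnc(F)nc1C(F)(F)F` differs from compound 2 by a single exchange: fluoro in place of chloro on an aromatic carbon. Neither measured step swaps one halogen for another at this carbon, so both bear only loosely on it; the large gain came from removing trifluoromethyl, and a halogen stays in place here. A modest step, if any beyond the scatter, is expected, with compound 4 estimated at 100 nM (range 30 nM to 400 nM), i.e. a 2.0-fold higher number from compound 2 to compound 4 (0.30 log units; within the scatter).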

Compound 4, half-maximal inhibitory concentration: 400 nM
Compound 4: middle estimate off by 4.0-fold (0.60 log units), on the low side; measured number inside the range.
By their numbers in this assay, from the lowest: compound 2; then compounds 3 and 4 (each within the scatter of the next). At a limit, above all of these: compound 1.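

At this carbon, between two ring nitrogen atoms, the choice of halogen matters: fluoro in place of chloro gives an 8.0-fold higher number from compound 2 to compound 4 (0.90 log units; beyond the scatter). Fluoro nevertheless stays well ahead of trifluoromethyl at the same carbon, with an at least 25-fold lower number from compound 1 to compound 4 (1.39 log units; beyond the scatter). That step is only a lower bound, set by compound 1: the limit of > 10000 nM in this assay, at which 1 of the 4 values shown sits.

Going by these compounds, whether bromo, an amine or a methoxy group at this carbon would give a number lower than that of compound 2 stays open. Also open, on these data alone, is whether chloro would still lead fluoro with the phenyl group of compound 3 in place.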